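Cytotoxicity of a cinnamoyl hydrazide and its dimethoxy analogue

A few compounds are considered here, and "the series" means these few. Any claim that something is new, unique, unknown or untested is made for them only; others in the source may bear on it.

Measured compounds:
- compound 1 `COc1cc(NC(C)CCCNC(=O)NCCO)c2ncccc2c1`: in an ADME assay on L6 cells (Rattus norvegicus) for cytotoxicity, read by resazurin assay, with a stated time of 70 h (a lower number here means a stronger inhibitor, a higher number a weaker inhibitor), compound 1 gives "not determined" (no result reported)
- compound 2 `COc1cc(NC(C)CCCNC(=O)NCc2ccncc2)c2ncccc2c1`: in this assay compound 2 gives "not determined" (no result reported)
- compound 3 `COc1cc(NC(C)CCCNC(=O)NNC(=O)/C=C/c2ccccc2)c2ncccc2c1`: in this assay compound 3 gives 13900 nM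

Going by the values given here, compound 3 stands alone on the numbers: it carries the only value in this assay, while compound 1 and compound 2 share the same core but have no reported result, so no comparison among measured compounds can be drawn.

Compound 4 `COc1cc(NC(C)CCCNC(=O)NNC(=O)/C=C/c2ccc(OC)c(OC)c2)c2ncccc2c1` is the next compound to be tested. It differs from compound 3 in one place: 3,4-dimethoxyphenyl in place of phenyl on a double-bonded chain carbon bound to a double-bonded chain carbon. Among the compounds with values here, no measured pair shows what such a change does here, so the expectation rests only on compound 3 itself. For the step from compound 3 to compound 4 in this assay a change of no more than the usual scatter is expected, with no clear direction, as estimated by a 1.1-fold higher number from compound 3 to compound 4 (0.03 log units; within the scatter). On that basis compound 4 is expected to give about 15000 nM, within a range from 5000 nM to 45000 nM.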

Compound 4, half-maximal inhibitory concentration: 37000 nM
Beside the measured number, compound 4's estimate is 2.5-fold (0.39 log units) below it; measured number inside the range.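

Compound 3 alone could not show whether this position matters, but the first measured pair shows that it does in this assay: there is a 2.7-fold higher number from compound 3 to compound 4 (0.43 log units; beyond the scatter) when 3,4-dimethoxyphenyl takes the place of phenyl on a double-bonded chain carbon bound to a double-bonded chain carbon. A higher number means a weaker inhibitor, so this change weakens the effect on the cells by a modest step that lies beyond the usual scatter. Nothing available here accounts for the shift.

This single pair leaves open whether both methoxy groups are needed for the step or one methoxy group would give the same result. It also leaves open how a different group at this place, such as an amine or a carboxylic acid, would move the number.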